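Swapping the Aryl on the Sulfur: Dimethoxy Out, Chloro In

The source may hold more compounds than are shown below. What is called first, only, known or untested is meant among the compounds shown, and "the series" means these compounds.

Compound 2 `COc1ccc(SCc2ccc(/C=C/C(=O)Nc3ccccc3N)cc2)cc1OC` gives 46% in a functional assay on A-375 cells (Homo sapiens) for inhibition, read by CCK-8 assay, with a stated time of 72 h, tested at 2 uM; on this read-out higher numbers stand for more inhibition of growth at the one concentration tested and lower numbers for less inhibition of growth. Among the three compounds measured it stands second highest: compound 3 `Nc1ccccc1NC(=O)c1ccc(CSc2nccc(C(F)(F)F)n2)cc1` gives 54.4%, within the scatter of compound 2, while compound 1 `Cc1ccc(SCc2ccc(/C=C/C(=O)Nc3ccccc3N)cc2)cc1` gives 22.9%, beyond the scatter below it. Compound 4 `Nc1ccccc1NC(=O)/C=C/c1ccc(CSc2ccc(Cl)cc2)cc1` has not yet been measured; it differs from compound 2 in one place: 4-chlorophenyl in place of 3,4-dimethoxyphenyl on a sulfur. Going by the values given here, the only measured step that bears on this change is a number 23.1 percentage points higher from compound 1 to compound 2 (beyond the scatter), where 3,4-dimethoxyphenyl replaced 4-methylphenyl. Because a number 23.1 percentage points higher from compound 1 to compound 2 (beyond the scatter) accompanied the arrival of a group with two hydrogen-bond acceptors where 4-methylphenyl has none, and 4-chlorophenyl likewise has none, much of that gain is expected to be undone, an estimated step of a number 18 percentage points lower from compound 2 to compound 4 (beyond the scatter). Compound 4 is therefore estimated at 28%, within a range from 12% to 46%.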

Compound 4, percent growth inhibition at one concentration: 13.4%
For compound 4 the middle estimate is 14.6 percentage points above the measured one; low and high end bracket the measured number.
By their numbers in this assay, from the lowest: compounds 4 and 1 (each within the scatter of the next); then compounds 2 and 3 (each within the scatter of the next).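

The aryl group on this sulfur clearly matters: with 4-chlorophenyl in place of 3,4-dimethoxyphenyl there is a number 32.6 percentage points lower from compound 2 to compound 4 (beyond the scatter), a large drop. Chloro in place of methyl leaves a number 9.5 percentage points lower from compound 1 to compound 4 (within the scatter), so those two groups cannot be told apart, and of the three aryl groups on this sulfur only 3,4-dimethoxyphenyl stands clearly apart from the others. Nothing measured here explains that difference. Still open, as far as these compounds go, is whether both methoxy groups are needed, and how an amine or a carboxylic acid on this ring would compare.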